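Swapping Allyl for 1,2-Oxazol-3-yl on the Amide Nitrogen

A few compounds are considered here, and "the series" means these few. Any claim that something is new, unique, unknown or untested is made for them only; others in the source may bear on it.

Compound 1 `COc1ccc2oc(C(=O)N(Cc3cccs3)c3ccn[nH]3)cc2c1`: 1.1 nM
Compound 2 `Cc1ccc(OCC(=O)N(Cc2cccs2)c2ncccn2)cc1`: 3700 nM
Compound 3 `C=CCN(Cc1cccs1)C(=O)COc1ccc(C)cc1`: 20 nM

In an assay on HEK293 cells for agonist activity at transient receptor potential cation channel subfamily M member 8 (Homo sapiens), read by fluorescence and calcium flux, with a stated time of 15 min (on this read-out higher numbers stand for an effect only at larger amounts of compound and lower numbers for an effect already at smaller amounts), compound 3 gives 20 nM, the second highest of the three numbers. Compound 1 gives the lowest number, and compound 2 the highest. Among the compounds with values here, the one measured step at the amide-type nitrogen is a 190-fold lower number from compound 2 to compound 3 (2.27 log units; beyond the scatter), where allyl replaced pyrimidin-2-yl. Compound 4 `Cc1ccc(OCC(=O)N(Cc2cccs2)c2ccon2)cc1` reverses that kind of move: 1,2-oxazol-3-yl in place of allyl on an amide-type nitrogen. Since an aromatic ring on this nitrogen gave compound 2 its high number, the number for compound 4 is expected to rise, though less sharply, because compound 1 carries a five-membered aromatic ring there and still gives 1.1 nM. The expected step is a 10-fold higher number from compound 3 to compound 4 (1.00 log units; beyond the scatter). Compound 4 is estimated at 200 nM, within 20 nM to 2000 nM.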

Compound 4, half-maximal effective concentration: 2 nM
Compound 4: the middle estimate sits 100-fold (2.00 log units) above what was measured; measured number below the stated range.
By their numbers in this assay, from the lowest: compounds 1 and 4 (each within the scatter of the next); then compound 3; then compound 2.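

In this assay, the step of a 10-fold lower number from compound 3 to compound 4 (1.00 log units; beyond the scatter) shows that an aromatic ring on this amide-type nitrogen can give a lower number than allyl. Exchanging one ring for another matters far more, with a 1900-fold lower number from compound 2 to compound 4 (3.27 log units; beyond the scatter) when 1,2-oxazol-3-yl takes the place of pyrimidin-2-yl, so the high number of compound 2 cannot be pinned on having an aromatic ring there as such. From the compounds shown here alone, whether a phenyl ring, a longer chain or an amine on this nitrogen would keep the number low remains open. Nothing available explains why these two rings differ so widely.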